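A few compounds are considered here, and "the series" means these few. Any claim that something is new, unique, unknown or untested is made for them only; others in the source may bear on it.

Measured compounds and their values:
compound 1, `COc1cc(/C(Cl)=C/C=C(\C#N)C(=O)c2c[nH]c3ccccc23)cc(OC)c1OC`, 73.3%
compound 2, `COc1ccc(/C(Cl)=C/C=C(\C#N)C(=O)c2c[nH]c3ccc(Br)cc23)cc1`, 56.2%
compound 3, `COc1ccc2[nH]cc(C(=O)/C(C#N)=C/C=C(\Cl)c3ccc(Br)cc3)c2c1`, 76.7%

In a functional assay for inhibition, read by Griess assay, with a stated time of 150 min, tested at 1 mM (a higher number here means more inhibition at the concentration tested (going by the name of the read-out), a lower number less inhibition), compound 1 gives 73.3%, the second highest of the three numbers. Its nearest neighbour is compound 3 with 76.7%, a difference that lies within the usual scatter, so no order between these two can be read from the numbers. The furthest is compound 2 with 56.2%, a difference that goes beyond the scatter, so compound 2 sits lower than compound 1 in this assay.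

Compound 4, `COc1cc(/C(Cl)=C/C=C(\C#N)C(=O)c2c[nH]c3ccc(Br)cc23)cc(OC)c1OC`, is not yet measured. It differs from compound 1 in one place: bromo in place of hydrogen on an aromatic carbon. The same difference, cut one bond further out, reads 1H-indol-3-yl to 5-bromo-1H-indol-3-yl.

Among the compounds with values here, no pair of measured compounds that differ only in this way has been measured, so the size of the step cannot be taken from the data. The change is small, a single heavy atom entering, and the expectation is a step of a number 3.3 percentage points lower from compound 1 to compound 4 (within the scatter), within the scatter in either direction. Compound 4 is therefore expected to give about 70%, between 50% and 85%.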

Compound 4, a percentage reported as inhibition, at one concentration (the size of the read-out at that concentration, not a potency): 36.7%
Estimate against measurement, compound 4: 33.3 percentage points above; the whole stated range lies above it.
By their numbers in this assay, from the lowest: compound 4; then compound 2; then compounds 1 and 3 (each within the scatter of the next).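

In this assay, bromo in place of hydrogen on an aromatic carbon of the six-membered aromatic ring of the fused system goes with a number 36.6 percentage points lower from compound 1 to compound 4 (beyond the scatter). This shows that the read-out at this position is sensitive to the entry of a single heavy atom, and that the step here is large. The earlier compounds shown here could not show this, since no two of them differed in one place only. Nothing measured here bears on the cause of this step.

From the compounds shown here alone, whether the loss belongs to bromo in particular or would also follow from a fluoro or an amine at the same carbon remains open. So does whether the step keeps its size when the rest of the structure differs, as this single pair gives only one reading of the change.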